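Benzyloxy in Place of Benzyl on the Nitrile Chain

This account rests on a few compounds, and the source may have more. Where it says the series, first, only, none or still open, it means among the compounds named here.

Three compounds share a core carrying a nitrile and a morpholine amide and have been measured in an assay on isolated protein for inhibition of cathepsin S (Homo sapiens); a lower number here means tighter binding, a higher number weaker binding. Compound 1 `N#CC1(NC(=O)[C@@H](CC(=O)N2CCOCC2)CC2CCCCC2)CC1` gives 12 nM. Compound 2 `CC1CCC(C[C@H](CC(=O)N2CCOCC2)C(=O)N[C@]2(C#N)CCN(C3CCCCC3)C2)CC1` gives 13.8 nM. Compound 3 `N#C[C@H](CCc1ccccc1)NC(=O)[C@@H](CC(=O)N1CCOCC1)CC1CCCCC1` gives 25 nM. Among these three numbers, compound 3 stands at the high end: its gap to compound 2 lies within the usual scatter, so the two cannot be told apart, while its gap to compound 1 lies beyond it, so compound 3 binds more weakly than compound 1.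

Compound 4 `N#C[C@H](COCc1ccccc1)NC(=O)[C@@H](CC(=O)N1CCOCC1)CC1CCCCC1` has not yet been measured. It differs from compound 3 in one place: benzyloxy in place of benzyl on a saturated chain carbon, two bonds along the chain from an amide-type nitrogen and a triple-bonded carbon. Among the compounds with values here, no measured pair shows the effect of such a change here, so there is no step to lean on. Given that, the step from compound 3 to compound 4 is expected to be small, with no clear direction and none beyond the scatter, and the expected step is no change at the digits printed from compound 3 to compound 4 (within the scatter). Compound 4 is therefore expected to give about 25 nM in this assay, with a likely range from 9 nM to 70 nM.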

Compound 4, dissociation constant: 4.39 nM
Compound 4: middle estimate off by 5.7-fold (0.76 log units), on the high side; the whole stated range lies above it.
By their numbers in this assay, from the lowest: compound 4; then compounds 1, 2 and 3 (each within the scatter of the next, the first and the last beyond it).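

In this assay, the saturated chain carbon, two bonds along the chain from an amide-type nitrogen and a triple-bonded carbon, proves sensitive to what it carries: benzyloxy in place of benzyl gives a 5.7-fold lower number from compound 3 to compound 4 (0.76 log units; beyond the scatter). Read from the other end of the same cut, phenethyl gives way to (benzyloxy)methyl, so the aromatic ring stays while the chain gains an oxygen and a hydrogen-bond acceptor. No evidence at hand accounts for this step.

Benzyloxy differs from benzyl in both its oxygen and its heavy-atom count, so this single pair cannot separate the two, and a benzylsulfanyl group or a plain phenylpropyl chain at this carbon would bear on that question. On these data alone, whether the step carries over to the differing nitrile portion of compound 2 also remains open.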